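The compounds below may be only part of what the source reports. "The series", "measured", "known", "first", "only" and "open" are said of these compounds alone.

Measured compounds in an ADME assay on THP-1 cells (Homo sapiens) for cytotoxicity; a higher number here means a weaker inhibitor, a lower number a stronger inhibitor:
- compound 1 `COc1ccccc1-c1nnc(-c2ccc(C(=O)N/N=C/c3cc(O)ccc3O)cc2)o1`: 100000 nM
- compound 2 `COc1ccccc1-c1nnc(-c2ccc(C(=O)N/N=C/c3ccc(F)cc3)cc2)o1`: 427000 nM
- compound 3 `COc1ccccc1-c1nnc(-c2ccc(C(=O)N/N=C/c3c(O)cc(O)cc3O)cc2)o1`: 12400 nM

Compound 1 holds the second highest number of the three. Its nearest neighbour is compound 2, reached by a 4.3-fold higher number from compound 1 to compound 2 (0.63 log units; beyond the scatter); the furthest is compound 3, reached by an 8.1-fold lower number from compound 1 to compound 3 (0.91 log units; beyond the scatter). Between the two ends of the set the gap is a 34-fold lower number from compound 2 to compound 3 (1.54 log units; beyond the scatter).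

Compound 4 `COc1ccccc1-c1nnc(-c2ccc(C(=O)N/N=C/c3ccccn3)cc2)o1` is not yet measured in this assay. It differs from compound 1 in one place: pyridin-2-yl in place of 2,5-dihydroxyphenyl on a carbon with a double bond to nitrogen.

Within the data shown here, the step that bears most directly on this change is the one from compound 1 to compound 2, where the 2,5-dihydroxyphenyl gives way to a ring without hydroxyl groups and the number rises by a 4.3-fold higher number from compound 1 to compound 2 (0.63 log units; beyond the scatter). The step from compound 1 to compound 3 points the other way, the extra hydroxyl groups lowering the number by an 8.1-fold lower number from compound 1 to compound 3 (0.91 log units; beyond the scatter). Pyridin-2-yl, like 4-fluorophenyl, carries no hydrogen-bond donor, so a rise in this assay on the order of the first step is expected, with wide uncertainty since no pyridinyl analogue has been measured. The expected step is a 3.0-fold higher number from compound 1 to compound 4 (0.48 log units; beyond the scatter). Compound 4 is estimated at 300000 nM, within a range of 100000 nM to 900000 nM.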

Compound 4, half-maximal inhibitory concentration: 67000 nM
For compound 4 the middle estimate is 4.5-fold (0.65 log units) above the measured one; measured number outside the range, below it.
By their numbers in this assay, from the lowest: compound 3; then compounds 4 and 1 (each within the scatter of the next); then compound 2.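

In this assay, pyridin-2-yl on this carbon stands level with 2,5-dihydroxyphenyl (a 1.5-fold lower number from compound 1 to compound 4 (0.17 log units; within the scatter)), so among the compounds shown, a ring with 0 hydrogen-bond donors can match the dihydroxyphenyl compound, which compound 2 alone did not show. The absence of hydroxyl groups therefore does not set the number by itself: the two rings without them are clearly separated (a 6.4-fold lower number from compound 2 to compound 4 (0.80 log units; beyond the scatter)), and the choice between pyridin-2-yl and 4-fluorophenyl matters at this position, while 2,4,6-trihydroxyphenyl still keeps its distance from pyridin-2-yl (a 5.4-fold higher number from compound 3 to compound 4 (0.73 log units; beyond the scatter)). Nothing available accounts for any of these differences.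

The compounds shown leave open how pyridin-3-yl, pyridin-4-yl and unsubstituted phenyl would fall in this series, and these groups would show whether the ring nitrogen or the fluorine is what separates compound 4 from compound 2. They also leave open whether a single hydroxyl, as in 4-hydroxyphenyl, or an amine on the ring would stand with compound 3 or with compound 4 on the same core.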